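Removing one methoxy group from a trimethoxy chalcone-like pyrazole

The source may hold more compounds than are shown below. What is called first, only, known or untested is meant among the compounds shown, and "the series" means these compounds.

Measured compounds:
- compound 1 `COc1ccc(-c2cc(/C=C/C(=O)c3ccc(N)cc3)[nH]n2)cc1`: -65%
- compound 2 `COc1cc(-c2cc(/C=C/C(=O)c3ccc(N)cc3)[nH]n2)cc(OC)c1OC`: -77%
- compound 3 `COc1ccc(C(=O)/C=C/c2cc(-c3cc(OC)c(OC)c(OC)c3)n[nH]2)cc1`: 19%

In a functional assay on MDA-MB-231 cells (Homo sapiens) for cytotoxicity, read by sulforhodamine B assay, with a stated time of 48 h, tested at 100 uM (a higher number here means a weaker effect of the compound at the concentration tested, a lower number a stronger effect), compound 2 gives the lowest of the three numbers, that is, the strongest effect. Compound 1 sits nearest to it, compound 3 furthest. For the measured compounds named here, the only measured single step here is a number 96 percentage points higher from compound 2 to compound 3 (beyond the scatter), but it concerns the exchange of amino for methoxy at the other end of the molecule, so it says nothing direct about the present change.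

Compound 4 `COc1ccc(-c2cc(/C=C/C(=O)c3ccc(N)cc3)[nH]n2)cc1OC` differs from compound 2 by hydrogen in place of methoxy on an aromatic carbon. Going by the values given here, no measured step covers this change. Compound 1, which carries a single methoxy group on that ring, and compound 2, which carries three, give numbers that lie fairly close, so a middle number is expected for the two-methoxy compound 4. The step of a number 7 percentage points higher from compound 2 to compound 4 (within the scatter) is therefore expected to be small, going toward a slightly weaker effect at most. For compound 4 the estimate is -70%, within -85% to -50%.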

Compound 4, a percentage reported as activity, at one concentration (the size of the read-out at that concentration, not a potency): -77%
Compound 4: middle estimate off by 7 percentage points, on the high side, and the stated range covers the measured number.
By their numbers in this assay, from the lowest: compounds 2 and 4 (each within the scatter of the next); then compound 1; then compound 3.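

Within this assay, this methoxy group, ortho to a methoxy group and meta to a large group, can give way to hydrogen with no visible consequence: there is no change at the digits printed from compound 2 to compound 4 (within the scatter). The neighbouring step on the same ring does register, with a number 12 percentage points lower from compound 1 to compound 4 (beyond the scatter) when methoxy takes the place of hydrogen, so on this ring going from one methoxy group to two moves the number, whereas going from two to three does not. Nothing available explains either step.

From the compounds shown here alone, whether this position would accept a hydroxyl group, a fluorine atom or an amine remains open, since only methoxy and hydrogen are compared here. Also open, going by these compounds, is whether hydrogen would be tolerated equally with methoxy in place of amino at the other end of the molecule.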